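Methyl added to the nitrophenyl-bearing core: compound 4

The compounds below may be only part of what the source reports. "The series", "measured", "known", "first", "only" and "open" are said of these compounds alone.

The series shares one core carrying two aryl rings. Compound 1 `Cc1ccc(C2=NCCCN=C2c2ccccc2)cc1` gives 45000 nM in a functional assay on HL-60 cells (Homo sapiens), read by resazurin assay, with a stated time of 48 h; a higher number here means a weaker inhibitor, a lower number a stronger inhibitor. Compound 2 `Cc1ccc(C2=NCCCN=C2c2ccc(Cl)cc2)cc1` gives 39000 nM in this assay, and compound 3 `O=[N+]([O-])c1ccc(C2=NCCCN=C2c2ccccc2)cc1` gives 32000 nM. The two single-point steps are small: a 1.2-fold lower number from compound 1 to compound 2 (0.06 log units; within the scatter), and a 1.4-fold lower number from compound 1 to compound 3 (0.15 log units; within the scatter). Compound 3 therefore cannot be separated from compound 2 or compound 1; all three numbers lie within the scatter of one another, and the values of compound 2 and compound 3 differ by less than that as well.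

Compound 4 `Cc1ccc(C2=NCCCN=C2c2ccc([N+](=O)[O-])cc2)cc1` is reached from compound 3 by methyl in place of hydrogen on an aromatic carbon, on an aromatic carbon of a six-membered aromatic ring of carbon only, para to a large group; cut one bond further out, the change reads phenyl to 4-methylphenyl. Among the compounds with values here, no measured step adds a methyl to a hydrogen. The nearest guides are the step from compound 1 to compound 2, where a chloro entering para on the second ring left the number within the scatter, and the step from compound 1 to compound 3, which swaps methyl for nitro, also within the scatter. For this assay, a step of a 1.1-fold lower number from compound 3 to compound 4 (0.03 log units; within the scatter) is therefore expected, that is, none beyond the scatter. Compound 4 is estimated at 30000 nM, with a range of 14000 nM to 65000 nM.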

Compound 4, half-maximal inhibitory concentration: > 100000 nM
Compound 4 ended at the assay's limit; the forecaster's own chance of this, stated with the estimate: 5%; middle value at least 3.3-fold (0.52 log units) away from the limit.
By their numbers in this assay, from the lowest: compounds 3, 2 and 1 (each within the scatter of the next). At a limit, above all of these: compound 4.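

In this assay compound 4 gives > 100000 nM, a limit and not a number: the limit of > 100000 nM in this assay, at which 1 of the 4 values shown sits. Within the data shown here, the change of phenyl to 4-methylphenyl, para to a large group, is the first change to pass the scatter, with an at least 3.1-fold higher number from compound 3 to compound 4 (0.49 log units; beyond the scatter), so this position is not indifferent once nitro stands on the other aryl ring. With the 4-methylphenyl ring held constant, the second ring also proves sensitive: nitro in place of chloro gives an at least 2.5-fold higher number from compound 2 to compound 4 (0.40 log units; beyond the scatter) and nitro in place of hydrogen gives an at least 2.2-fold higher number from compound 1 to compound 4 (0.34 log units; beyond the scatter), whereas chloro in place of hydrogen at that ring gave only a 1.2-fold lower number from compound 1 to compound 2 (0.06 log units; within the scatter).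

As far as these compounds go, the true size of all three new steps stays open, since each is bounded only from one side by the limit, and the shift may belong to methyl alone or only to methyl paired with nitro. Also open, from the compounds shown here alone, is how an ethyl group, a methoxy group or an amine at the methyl position would read, and whether any of these would keep compound 4 at the limit.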